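A few compounds are considered here, and "the series" means these few. Any claim that something is new, unique, unknown or untested is made for them only; others in the source may bear on it.

Measured compounds:
Compound 1 `Cc1nn(-c2ccccc2)c2nc(C(=O)N3NC(=O)/C(=C/c4ccc(Cl)cc4)N=C3c3ccc(Cl)cc3)[nH]c(=O)c12`; in a functional assay on HCT-116 cells (Homo sapiens) for cytotoxicity, read by MTT assay, with a stated time of 48 h (a higher number here means a weaker inhibitor, a lower number a stronger inhibitor), compound 1 gives 15 nM.
Compound 2 `Cc1nn(-c2ccccc2)c2nc(C(=O)N3NC(=O)/C(=C/c4ccc(Cl)cc4)N=C3c3ccccc3)[nH]c(=O)c12`; in this assay compound 2 gives 28.1 nM.
Compound 3 `Cc1ccc(C2=N/C(=C\c3ccccc3)C(=O)NN2C(=O)c2nc3c(c(C)nn3-c3ccccc3)c(=O)[nH]2)cc1`; in this assay compound 3 gives 46.5 nM.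

Compound 2 stands second highest of the three numbers. Its nearest neighbour is compound 3 and its furthest is compound 1, and both gaps lie within the scatter, so these three compounds cannot be ordered on the numbers shown. Compound 4 `COc1ccc(/C=C2\N=C(c3ccccc3)N(C(=O)c3nc4c(c(C)nn4-c4ccccc4)c(=O)[nH]3)NC2=O)cc1` has not yet been tested. It differs from compound 2 in one place: methoxy in place of chloro on an aromatic carbon. Among the measured compounds shown here, the only measured step touching this position is a 1.9-fold higher number from compound 1 to compound 2 (0.27 log units; within the scatter), which exchanges chloro for hydrogen rather than for methoxy. For the measured compounds named here, no measured pair shows methoxy entering, so the data give no direct guide to this exact change. Because that one related step of a 1.9-fold higher number from compound 1 to compound 2 (0.27 log units; within the scatter) stayed within the scatter, no step beyond the scatter is expected in this assay in either direction for compound 4. Compound 4 is therefore estimated at 30 nM, with a range from 12 nM to 75 nM. This estimate means an expected step of a 1.1-fold higher number from compound 2 to compound 4 (0.03 log units; within the scatter), which is expected to lie within the scatter.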

Compound 4, half-maximal inhibitory concentration: 52.1 nM
The estimate for compound 4 lay 1.7-fold (0.24 log units) below the measured number, within the range that was stated.
By their numbers in this assay, from the lowest: compounds 1, 2, 3 and 4 (each within the scatter of the next, the first and the last beyond it).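

Compound 4 gives the first measured case of methoxy entering on this ring: in this assay, the change from 4-chlorophenyl to 4-methoxyphenyl gives a 1.9-fold higher number from compound 2 to compound 4 (0.27 log units; within the scatter). On an aromatic carbon para to a large group, chloro and methoxy therefore cannot be told apart in this assay, even though methoxy brings a hydrogen-bond acceptor and one more heavy atom than chloro. No independent measurement is available to explain this outcome.

The compounds shown leave open whether any group at this place would produce a step beyond the scatter, for instance an amine, a carboxylic acid or a longer alkoxy chain. Among the compounds shown here, they also include no pair that isolates hydrogen at this carbon against chloro or methoxy, so the effect of having no substituent here remains unread.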